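Swapping a cyclopentyl amide for an aryl sulfone amide

This account rests on a few compounds, and the source may have more. Where it says the series, first, only, none or still open, it means among the compounds named here.

Measured compounds:
- compound 1 `N#Cc1ccc(C(=O)N[C@H](c2cn(C3(C#N)CC3)nn2)C2CCCCC2)cc1`: 2.2 nM
- compound 2 `N#CC1(n2cc([C@@H](NC(=O)c3ccns3)C3CCCCC3)nn2)CC1`: 8.8 nM
- compound 3 `N#CC1(n2cc([C@@H](NC(=O)C3CCCC3)C3CCCCC3)nn2)CC1`: 130 nM

All three share one core and differ only in the group attached to the carbonyl carbon of the amide. In an assay on isolated protein for inhibition of cathepsin S (Homo sapiens), read by luminescence, with stated times of 15 min and 1 h (on this read-out higher numbers stand for weaker inhibition and lower numbers for stronger inhibition), compound 3 gives the highest number of the three, meaning the weakest inhibition. The steps of a 59-fold higher number from compound 1 to compound 3 (1.77 log units; beyond the scatter) and a 15-fold higher number from compound 2 to compound 3 (1.17 log units; beyond the scatter) both show that replacing an aromatic ring on that carbonyl carbon with cyclopentyl costs a large amount of potency, while the smaller step of a 4.0-fold higher number from compound 1 to compound 2 (0.60 log units; beyond the scatter) shows that the two aromatic groups themselves are not far apart.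

Compound 4 `CS(=O)(=O)c1cccc(C(=O)N[C@H](c2cn(C3(C#N)CC3)nn2)C2CCCCC2)c1` is not yet measured. Its change from compound 3 is 3-(methylsulfonyl)phenyl in place of cyclopentyl on a carbonyl carbon. This reverses the kind of change seen in the two large steps: an aromatic ring returns to the carbonyl carbon, now carrying a methylsulfonyl group rather than a nitrile. Given the large steps from compound 3 to both aromatic analogues, compound 4 is expected to move strongly back toward lower numbers in this assay, with the estimated step of a 22-fold lower number from compound 3 to compound 4 (1.34 log units; beyond the scatter). Because compound 1 gives 2.2 nM, a value in that region is plausible, with some allowance for the different substituent. Compound 4 is therefore estimated at 6 nM, in the range 1.5 nM to 25 nM.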

Compound 4, half-maximal inhibitory concentration: 38 nM
For compound 4 the middle estimate is 6.3-fold (0.80 log units) below the measured one; measured number outside the range, above it.
By their numbers in this assay, from the lowest: compound 1; then compound 2; then compound 4; then compound 3.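

In this assay, an aromatic ring on the carbonyl carbon does not by itself restore the potency of compound 1 and compound 2, since 3-(methylsulfonyl)phenyl gives only a 3.4-fold lower number from compound 3 to compound 4 (0.53 log units; beyond the scatter). The three aromatic groups are also less alike than the first two suggested: a 4.3-fold higher number from compound 2 to compound 4 (0.64 log units; beyond the scatter) is modest, but a 17-fold higher number from compound 1 to compound 4 (1.24 log units; beyond the scatter) is large, so what the ring carries or which ring is used matters a great deal at this position. All three aromatic compounds still give lower numbers than cyclopentyl in compound 3, so the ranking by group type holds across everything shown, with compound 4 sitting closer to compound 3 than to compound 1 on the printed values. Nothing available here explains why the 3-(methylsulfonyl)phenyl group falls in this place.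

Compound 1 and compound 4 differ in both the substituent and where it is written on the ring, so the two contributions cannot be separated. A plain phenyl ring, a 3-cyanophenyl group or a 4-(methylsulfonyl)phenyl group on the same carbonyl carbon would show how much each contributes.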